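From a carboxy side chain to an ethoxycarbonyl one

The compounds below may be only part of what the source reports. "The series", "measured", "known", "first", "only" and "open" are said of these compounds alone.

In a functional assay on MCF7 cells (Homo sapiens) for inhibition, read by MTT assay, with a stated time of 3 days (on this read-out higher numbers stand for weaker inhibition and lower numbers for stronger inhibition), compound 1 (`CC[C@H](C)[C@H](NCC(=O)NNC(=O)COc1ccc(-c2nc3ccccc3s2)cc1OC)C(=O)O`) gives 1710 nM, compound 2 (`COc1cc(-c2nc3ccccc3s2)ccc1OCC(=O)NNC(=O)CN[C@@H](CS)C(=O)O`) gives 1230 nM and compound 3 (`COc1cc(-c2nc3ccccc3s2)ccc1OCC(=O)NNC(=O)CN[C@@H](CCSC)C(=O)O`) gives 1950 nM, so compound 3 stands within the scatter of both others. The measured steps are a 1.4-fold lower number from compound 1 to compound 2 (0.14 log units; within the scatter), a 1.1-fold higher number from compound 1 to compound 3 (0.06 log units; within the scatter) and a 1.6-fold higher number from compound 2 to compound 3 (0.20 log units; within the scatter). Each of them only exchanges the side chain on a saturated chain carbon bound to an amine nitrogen and a carbonyl carbon, and the carboxy group stays in all three compounds.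

Compound 4 (`CCOC(=O)CN(C)CC(=O)NNC(=O)COc1ccc(-c2nc3ccccc3s2)cc1OC`) differs from compound 3 more deeply: ((ethoxycarbonyl)methyl)(methyl)amino in place of (1-carboxy-3-(methylsulfanyl)propyl)amino on a saturated chain carbon bound to a carbonyl carbon. Going by the values given here, the carboxy group is gone, and no measured step covers such a change. The three steps therefore bear on it only indirectly, and they offer no direction. No shift beyond the scatter is expected, but the uncertainty is wide. The expected step is a 1.1-fold lower number from compound 3 to compound 4 (0.06 log units; within the scatter). For compound 4 the estimated value is 1700 nM, with an expected range of 650 nM to 4500 nM.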

Compound 4, half-maximal inhibitory concentration: 1980 nM
Estimate against measurement, compound 4: 1.2-fold (0.07 log units) below; the range from low to high includes it.
By their numbers in this assay, from the lowest: compounds 2, 1, 3 and 4 (each within the scatter of the next).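

In this assay, ((ethoxycarbonyl)methyl)(methyl)amino in place of the earlier side chains gives steps that all lie within the scatter (a 1.0-fold higher number from compound 3 to compound 4 (0.01 log units; within the scatter); a 1.6-fold higher number from compound 2 to compound 4 (0.21 log units; within the scatter); a 1.2-fold higher number from compound 1 to compound 4 (0.06 log units; within the scatter)). Compounds 1, 2 and 3 all keep the carboxy group, so only compound 4 shows that, on a saturated chain carbon bound to a carbonyl carbon, the number stays within the scatter without that group, and also without the defined stereocentre and hydrogen-bond donors of the group it replaces. No measurement given here explains this result.

Since several features change together, the compounds shown do not separate the loss of the carboxy group from the addition of the methyl on the amine. Also open, as far as these compounds go, is how a primary amide or a benzyl ester in place of the ethoxycarbonyl group would read.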